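Fluoro Added to the 3-Bromophenyl Ring of Compound 2

The compounds below may be only part of what the source reports. "The series", "measured", "known", "first", "only" and "open" are said of these compounds alone.

Compound 1, `C=CCn1c(=O)/c(=C\c2cccc(Cl)c2)[nH]c(=O)/c1=C\c1ccccc1OC`: 4500 nM in a functional assay on HL-60 cells (Homo sapiens) for cytotoxicity, read by CCK-8 assay, with a stated time of 72 h; on this read-out lower numbers stand for stronger inhibition and higher numbers for weaker inhibition
Compound 2, `C=CCn1c(=O)/c(=C\c2cccc(Br)c2)[nH]c(=O)/c1=C\c1ccccc1OC`: 5200 nM in this assay

Among these two numbers compound 2 carries the higher one, but it is separated from compound 1 only by a 1.2-fold higher number from compound 1 to compound 2 (0.06 log units; within the scatter), a gap within the scatter, so the two compounds cannot be told apart on potency.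

Compound 3, `C=CCn1c(=O)/c(=C\c2ccc(F)c(Br)c2)[nH]c(=O)/c1=C\c1ccccc1OC`, differs from compound 2 by fluoro in place of hydrogen on an aromatic carbon. For the measured compounds named here, the single measured step, the swap of bromo for chloro on that ring, was small; no measured step adds a fluoro to any ring, so there is no direct precedent. Given how little that ring has responded so far, the expectation for compound 3 in this assay is a step of a 1.0-fold lower number from compound 2 to compound 3 (0.02 log units; within the scatter), not beyond the scatter. Compound 3 is therefore estimated at 5000 nM, with a range from 2500 nM to 10000 nM.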

Compound 3, half-maximal inhibitory concentration: "not active" (no number reported)
For compound 3 the study gives words and no number, and the estimate cannot be compared.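

For the compounds shown here, compound 3 is reported in this assay only as "not active", without a number, so no step from compound 2 to compound 3 can be read. The compounds shown leave open how much adding the fluoro changes potency. No supporting measurement bears on this result.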